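Same Hydroxyl Shift Tried on a Second Core

The source may hold more compounds than are shown below. What is called first, only, known or untested is meant among the compounds shown, and "the series" means these compounds.

Compound 1 `Oc1cccc(-c2cc(-c3ccsc3)cc(-c3ccccc3O)n2)c1`: > 50000 nM in a functional assay on HCT-15 cells (Homo sapiens) for cytotoxicity, read by CCK-8 assay (on this read-out lower numbers stand for stronger inhibition and higher numbers for weaker inhibition), a limit of the assay.
Compound 2 `Oc1cccc(-c2cc(-c3ccsc3)cc(-c3cccc(O)c3)n2)c1`: 1630 nM in this assay.
Compound 3 `Oc1cccc(-c2cc(-c3ccccn3)cc(-c3ccccc3O)n2)c1`: > 50000 nM in this assay, a limit of the assay.

The change 3-hydroxyphenyl in place of 2-hydroxyphenyl on an aromatic carbon gave an at least 30-fold lower number from compound 1 to compound 2 (1.48 log units; beyond the scatter). The cores of compound 1 and compound 3 differ by pyridin-2-yl in place of thiophen-3-yl on an aromatic carbon, a step of which a step that the two limits leave unreadable from compound 1 to compound 3, because of the limit of > 50000 nM in this assay, at which 2 of the 3 values shown sit. Compound 4 `Oc1cccc(-c2cc(-c3ccccn3)cc(-c3cccc(O)c3)n2)c1` has not been measured in this assay. It differs from compound 3 by 3-hydroxyphenyl in place of 2-hydroxyphenyl on an aromatic carbon, the same kind of change as from compound 1 to compound 2, though the place is meta to a pyridin-2-yl group rather than meta to a thiophen-3-yl group. The expected step is an at least 10-fold lower number from compound 3 to compound 4 (1.00 log units; beyond the scatter), resting on an at least 30-fold lower number from compound 1 to compound 2 (1.48 log units; beyond the scatter); as compound 3 sits at a limit, the expected size is uncertain. Compound 4 is estimated at 5000 nM, between 1000 nM and 50000 nM.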

Compound 4, half-maximal inhibitory concentration: 3510 nM
Beside the measured number, compound 4's estimate is 1.4-fold (0.15 log units) above it; the measured number falls inside the stated range.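

Moving the hydroxyl group from 2-hydroxyphenyl to 3-hydroxyphenyl also helps on the second core, with an at least 14-fold lower number from compound 3 to compound 4 (1.15 log units; beyond the scatter). In this assay the change therefore points the same way with thiophen-3-yl and with pyridin-2-yl, but that rests on these two pairs alone, and how closely the sizes match cannot be read: the same change on two cores in this assay, an at least 30-fold lower number (1.48 log units; beyond the scatter) from compound 1 to compound 2 and an at least 14-fold lower number (1.15 log units; beyond the scatter) from compound 3 to compound 4; the limit leaves it open whether they differ With 3-hydroxyphenyl in place, putting pyridin-2-yl where thiophen-3-yl stood gives a 2.2-fold higher number from compound 2 to compound 4 (0.33 log units; beyond the scatter), a modest step.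

The compounds shown leave open whether a 4-hydroxyphenyl group would give a lower number still. They also leave open whether the change would carry over to a core with an amine in place of pyridin-2-yl.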